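The compounds below may be only part of what the source reports. "The series", "measured", "known", "first", "only" and "open" are said of these compounds alone.

Compound 3 `CC(C)(C)/[N+]([O-])=C/c1cn(-c2ccc(F)cc2)nn1` is the fluoro-bearing member of the series. In a functional assay on MDA-MB-231 cells (Homo sapiens) for inhibition, read by MTT assay, with a stated time of 24 h (on this read-out lower numbers stand for stronger inhibition and higher numbers for weaker inhibition), compound 3 gives 66400 nM, the higher of the two numbers available. Compound 2 `CC(C)(C)/[N+]([O-])=C/c1cn(-c2ccccc2)nn1` carries hydrogen in that place and gives 14800 nM in this assay; the step of a 4.5-fold higher number from compound 2 to compound 3 (0.65 log units; beyond the scatter). Compound 1 `COc1ccc(-n2cc(/C=[N+](\[O-])Cc3ccccc3)nn2)cc1` gives > 100000 nM in this assay, which is a limit of the assay rather than a number. Compound 4 `COc1ccc(-n2cc(/C=[N+](\[O-])C(C)(C)C)nn2)cc1` differs from compound 3 by methoxy in place of fluoro on an aromatic carbon. Within the data shown here, no measured step exchanges fluoro for methoxy, and the only methoxy compound shows a limit, so the direction is open; the single step at this position was modest. Compound 4 is expected at 40000 nM (range 12000 nM to 150000 nM), an expected step of a 1.7-fold lower number from compound 3 to compound 4 (0.22 log units; within the scatter).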

Compound 4, half-maximal inhibitory concentration: 23100 nM
Estimate against measurement, compound 4: 1.7-fold (0.24 log units) above; measured number inside the range.
By their numbers in this assay, from the lowest: compounds 2 and 4 (each within the scatter of the next); then compound 3. At a limit, above all of these: compound 1.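

In this assay, methoxy in place of fluoro gives a 2.9-fold lower number from compound 3 to compound 4 (0.46 log units; beyond the scatter), while methoxy in place of hydrogen gives a 1.6-fold higher number from compound 2 to compound 4 (0.19 log units; within the scatter), so among these three groups on the aromatic carbon, fluoro alone stands apart. The change from benzyl to tert-butyl on the double-bonded nitrogen gives an at least 4.3-fold lower number from compound 1 to compound 4 (0.63 log units; beyond the scatter), but its size is bounded only, as compound 1 stands at a limit: the limit of > 100000 nM in this assay, at which 1 of the 4 values shown sits.

On these data alone, whether an amine or a carboxylic acid at the aromatic carbon would track fluoro or the other two groups remains open. So does whether the benzyl compounds would leave the limit with any other group on that carbon.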